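Cyclopropyl gives way to phenyl on a carbonyl carbon

The source may report more compounds than this note shows. Statements on the series, on what has been measured and on what is new or still open speak of the compounds shown alone.

In an ADME assay on the whole organism for pharmacokinetics, with Rattus norvegicus as the target (on this read-out higher numbers stand for a longer-lived compound and lower numbers for a shorter-lived compound), compound 1 `CCCS(=O)(=O)c1cc(C)cc(C)c1NC(=O)c1sccc1S(=O)(=O)Nc1onc(C)c1Cl` gives 1.3 h, compound 2 `Cc1cc(C)c(NC(=O)c2sccc2S(=O)(=O)Nc2onc(C)c2Cl)c(-c2ncco2)c1` gives 5.3 h and compound 3 `Cc1cc(C)c(NC(=O)c2sccc2S(=O)(=O)Nc2onc(C)c2Cl)c(C(=O)C2CC2)c1` gives 5.4 h. Compound 3 therefore stands well clear of compound 1 but within the scatter of compound 2. Compound 4 `Cc1cc(C)c(NC(=O)c2sccc2S(=O)(=O)Nc2onc(C)c2Cl)c(C(=O)c2ccccc2)c1` carries one change (phenyl in place of cyclopropyl on a carbonyl carbon), phenyl in place of cyclopropyl on a carbonyl carbon. Within the data shown here, no measured step makes this exact swap. Replacing propylsulfonyl gave modest steps, a 4.1-fold higher number from compound 1 to compound 2 (0.61 log units; beyond the scatter) and a 4.2-fold higher number from compound 1 to compound 3 (0.62 log units; beyond the scatter). The closer comparison is cyclopropylcarbonyl in place of 1,3-oxazol-2-yl, which gave a 1.0-fold higher number from compound 2 to compound 3 (0.01 log units; within the scatter). On that evidence, no step beyond the scatter is expected, and the estimated step is a 1.1-fold lower number from compound 3 to compound 4 (0.03 log units; within the scatter). In this assay compound 4 is expected at 5 h, within an estimated range of 2.3 h to 10.5 h.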

Compound 4, half-life: 3.95 h
Beside the measured number, compound 4's estimate is 1.3-fold (0.10 log units) above it; the measured number falls inside the stated range.
By their numbers in this assay, from the lowest: compound 1; then compounds 4, 2 and 3 (each within the scatter of the next).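

In this assay, an aromatic six-membered ring on the carbonyl carbon does about as well as the three-membered ring, with a 1.4-fold lower number from compound 3 to compound 4 (0.14 log units; within the scatter). Benzoyl also stays level with 1,3-oxazol-2-yl, with a 1.3-fold lower number from compound 2 to compound 4 (0.13 log units; within the scatter), and it keeps a clear edge over propylsulfonyl, with a 3.0-fold higher number from compound 1 to compound 4 (0.48 log units; beyond the scatter). Nothing available explains these numbers.

Still open, as far as these compounds go, is whether this carbonyl carbon accepts a group quite unlike these two rings, such as an amine or a longer chain. A carboxylic acid on the phenyl ring of benzoyl is equally untested in these compounds.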